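The source may hold more compounds than are shown below. What is called first, only, known or untested is meant among the compounds shown, and "the series" means these compounds.

Measured compounds:
- compound 2 `COc1ccc(Cn2cc(/C=N\NC(=O)c3c[nH]c4ccc(Br)cc34)c3ccc(F)cc32)cc1`: 67500 nM
- compound 1 `COc1ccc(Cn2cc(/C=N\NC(=O)c3c[nH]c4ccccc34)c3ccccc32)cc1`: 43900 nM
- compound 3 `O=C(N/N=C\c1cn(Cc2ccc(Cl)cc2)c2cc(F)ccc12)c1c[nH]c2ccc(Br)cc12`: 12500 nM

In a functional assay on DU-145 cells (Homo sapiens) for cytotoxicity (on this read-out higher numbers stand for weaker inhibition and lower numbers for stronger inhibition), compound 2 gives 67500 nM, the highest of the three numbers. Within the data shown here, compound 1 gives 43900 nM, which lies within the scatter of the number for compound 2; these two compounds differ in more than one place, so no single step joins them. Compound 3 gives 12500 nM; the step from compound 2 to compound 3 is a 5.4-fold lower number from compound 2 to compound 3 (0.73 log units; beyond the scatter), a change on the benzyl group rather than on the indole bound to the carbonyl.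

Compound 4 `COc1ccc(Cn2cc(/C=N\NC(=O)c3cn(C)c4ccccc34)c3ccc(F)cc32)cc1` differs from compound 2 in one place: 1-methyl-1H-indol-3-yl in place of 5-bromo-1H-indol-3-yl on a carbonyl carbon. Among the measured compounds shown here, no measured step touches this part of the molecule, so nothing in the data bears directly on the change. Without such a step, the expectation for compound 4 is a number close to that of compound 2, with no step beyond the scatter: the expected step is a 1.4-fold lower number from compound 2 to compound 4 (0.13 log units; within the scatter). Compound 4 is therefore estimated at 50000 nM, with a range from 15000 nM to 160000 nM.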

Compound 4, half-maximal inhibitory concentration: 15200 nM
Compound 4: middle estimate off by 3.3-fold (0.52 log units), on the high side; the measured number falls inside the stated range.
By their numbers in this assay, from the lowest: compounds 3 and 4 (each within the scatter of the next); then compounds 1 and 2 (each within the scatter of the next).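

In this assay, 1-methyl-1H-indol-3-yl in place of 5-bromo-1H-indol-3-yl on a carbonyl carbon gives a 4.4-fold lower number from compound 2 to compound 4 (0.65 log units; beyond the scatter), which shows that the number responds to a change at this place as well as to the earlier change on the benzyl group. The step combines two changes, as the bromo group leaves, a methyl group enters, and the hydrogen-bond donor counted on the leaving group is absent from the entering one. No measurement at hand gives a reason for the step.

The compounds shown leave open which of these changes carries the step, as no single-place comparison separates them. Going by these compounds, it also remains open how the number would respond to a propyl chain in place of the methyl or an amine in place of the bromo.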